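This account rests on a few compounds, and the source may have more. Where it says the series, first, only, none or still open, it means among the compounds named here.

Measured so far in an assay on HEK293 cells for agonist activity at Toll-like receptor 8 (Homo sapiens), read by spectrophotometry; a lower number here means that less compound is needed, a higher number that more compound is needed for the effect:
compound 1 `CCCCNc1nc(N)nc(C)c1CCCC(C)(C)O` gives 1220 nM;
compound 2 `CCCCNc1nc(N)nc(C)c1CCCN(C)C` gives 126 nM.

Compound 2 stands lowest of the two numbers; the step from compound 1 to compound 2 was a 9.7-fold lower number from compound 1 to compound 2 (0.99 log units; beyond the scatter). Compound 3 `CCCCNc1nc(N)nc(C)c1CCC(C)(C)O` carries 1-hydroxy-1-methylethyl in place of (dimethylamino)methyl on a saturated chain carbon, two bonds along the chain from an aromatic carbon, so the chain is one carbon shorter than in compound 1 but ends in the same group. For the measured compounds named here, the only measured step bearing on it is a 9.7-fold lower number from compound 1 to compound 2 (0.99 log units; beyond the scatter), and its reversal suggests the number should rise again by a step of similar size. Compound 3 is therefore expected to give 1000 nM (range 400 nM to 3000 nM), a step of a 7.9-fold higher number from compound 2 to compound 3 (0.90 log units; beyond the scatter).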

Compound 3, half-maximal effective concentration: 3140 nM
Beside the measured number, compound 3's estimate is 3.1-fold (0.50 log units) below it, and the stated range ends below it.
By their numbers in this assay, from the lowest: compound 2; then compound 1; then compound 3.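

In this assay, the length of the chain also counts: 1-hydroxy-1-methylethyl in place of 2-hydroxy-2-methylpropyl, on a saturated chain carbon, gives a 2.6-fold higher number from compound 1 to compound 3 (0.41 log units; beyond the scatter). Exchanging (dimethylamino)methyl for 1-hydroxy-1-methylethyl at that place gives a larger change, a 25-fold higher number from compound 2 to compound 3 (1.40 log units; beyond the scatter), so among these three compounds the end group moves the number further than the shortening does. No supporting data on hand account for either step. From the compounds shown here alone, it remains open whether a primary amine or a carboxylic acid at the chain end would keep a number as low as that of compound 2. Going by these compounds, the effect of a longer chain carrying the dimethylamino group is also open.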